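This account rests on a few compounds, and the source may have more. Where it says the series, first, only, none or still open, it means among the compounds named here.

Values in a functional assay on the whole organism (Tail, strain ICR) with Mus musculus as the target, in the tail flick test, with a stated time of 120 min, at a dose of 25 umol/kg by the oral route (on this read-out higher numbers stand for a stronger effect at the one dose given and lower numbers for a weaker effect), for the three measured compounds:
compound 1, `C[C@@H](O)[C@H](NC(=O)CN(c1nc(Cl)nc2[nH]cnc12)C1CC1)C(=O)OCc1ccccc1`, gives 30.7%
compound 2, `C[C@@H](O)[C@H](NC(=O)CN(c1nc(Cl)nc2[nH]cnc12)C1CC1)C(=O)O`, gives 37.6%
compound 3, `CC(C)C[C@H](NC(=O)CN(c1nc(Cl)nc2[nH]cnc12)C1CC1)C(=O)OCc1ccccc1`, gives 8.58%

Compound 4, `CC(C)C[C@H](NC(=O)CN(c1nc(Cl)nc2[nH]cnc12)C1CC1)C(=O)O`, has not yet been measured in this assay.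

Compound 2 is obtained from compound 1 by hydrogen in place of benzyl on an oxygen next to a carbonyl group; that step reads a number 6.9 percentage points higher from compound 1 to compound 2 (within the scatter). Compound 4 stands to compound 3 in the same way: hydrogen in place of benzyl on an oxygen next to a carbonyl group. The two place descriptions agree word for word, so this is the same change made on two different cores. The cores themselves differ as isobutyl in place of 1-hydroxyethyl on a saturated chain carbon bound to an amide-type nitrogen and a carbonyl carbon, and that difference alone reads a number 22.1 percentage points lower from compound 1 to compound 3 (beyond the scatter), which leaves compound 3 with the lowest of the three measured numbers.

Compound 4 is expected to show a number 6.4 percentage points higher from compound 3 to compound 4 (within the scatter), because the same change on the other core gave a number 6.9 percentage points higher from compound 1 to compound 2 (within the scatter). A single earlier instance of the change is a thin basis, so the range is kept wide. Compound 4 is therefore estimated at 15%, with 3% to 30% as the expected range.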

Compound 4, a percentage reported as activity, at one dose (the size of the read-out at that dose, not a potency): 18.7%
Compound 4: middle estimate off by 3.7 percentage points, on the low side; measured number inside the range.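

In this assay, hydrogen in place of benzyl gives a number 10.1 percentage points higher from compound 3 to compound 4 (beyond the scatter), so the change points the same way on both cores, with steps of matching size: the same change on two cores in this assay, a number 6.9 percentage points higher (within the scatter) from compound 1 to compound 2 and a number 10.1 percentage points higher (beyond the scatter) from compound 3 to compound 4, 3.2 percentage points apart, within the scatter of two such steps. Isobutyl in place of 1-hydroxyethyl, read on the pair carrying the carboxy group, gives a number 18.9 percentage points lower from compound 2 to compound 4 (beyond the scatter), and this change also keeps its size from one side of the series to the other: the same change on two cores in this assay, a number 22.1 percentage points lower (beyond the scatter) from compound 1 to compound 3 and a number 18.9 percentage points lower (beyond the scatter) from compound 2 to compound 4, 3.2 percentage points apart, within the scatter of two such steps. These two comparisons rest on the same four compounds at a single dose and time, so they show that the two changes combine without a visible interaction here, but not that either step would hold on any other core or that it reflects a difference in potency.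

Still open, going by these compounds, is how a methyl ester or a primary amide would read in place of the benzyl ester or the carboxy group. Also open, on these data alone, is whether a side chain bearing an amine, or a longer chain, would follow the same steps.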